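The source may report more compounds than this note shows. Statements on the series, on what has been measured and on what is new or still open speak of the compounds shown alone.

Measured compounds:
Compound 1 `COc1cccc(OC)c1C(=O)Nc1c[nH]nc1C(=O)NC1CC1`: in an ADME assay on MRC5 cells (Homo sapiens) for inhibition, with a stated time of 72 h (a lower number here means that less compound is needed, a higher number that more compound is needed for the effect), compound 1 gives > 50000 nM, which is a limit of the assay rather than a number.
Compound 2 `CO[C@H]1CC[C@H](NC(=O)c2n[nH]cc2NC(=O)c2cnc3ccccn23)CC1`: in this assay compound 2 gives 5900 nM.

Compound 1 stands at the limit of > 50000 nM in this assay, at which 1 of the 2 values shown sits, so for this compound only a boundary is known. For the measured compounds named here, no step between compound 1 and compound 2 can be stated beyond what the two values show: compound 2 returns a number, compound 1 does not.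

Compound 3 `COc1cccc(OC)c1C(=O)Nc1c[nH]nc1C(=O)NCCCN(C)C` has not yet been measured in this assay. It differs from compound 1 in one place: 3-(dimethylamino)propyl in place of cyclopropyl on an amide-type nitrogen. Going by the values given here, no measured pair shows the effect of this change, and with compound 1 sitting at a limit the step cannot be anchored to a measured difference. The expectation is that compound 3 stays near that limit, with a step that the limit leaves unreadable from compound 1 to compound 3 that is expected not to exceed the scatter. Compound 3 is therefore estimated at 60000 nM, between 20000 nM and 200000 nM, with a real chance that only a limit is reported again.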

Compound 3, half-maximal effective concentration: > 50000 nM
Compound 3: only a limit was reported; the forecaster's own chance of this, stated with the estimate: 70%; the middle value does not contradict the limit.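

In this assay compound 1 and compound 3 both return only a limit of the assay, so no step can be read between them: the limit of > 50000 nM in this assay, at which 2 of the 3 values shown sit. The compounds shown leave open how far 3-(dimethylamino)propyl in place of cyclopropyl actually moves the value.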